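The compounds below may be only part of what the source reports. "The series", "measured", "known", "first", "only" and "open" are said of these compounds alone.

In a functional assay on K562 cells (Homo sapiens) for inhibition, read by CCK-8 assay, with a stated time of 72 h (a higher number here means a weaker inhibitor, a lower number a stronger inhibitor), compound 1 `O=C(/C=C/c1cccnc1)NCCCc1cccc(S(=O)(=O)Nc2ccccc2)c1` gives 86.8 nM, while compound 2 `Cc1cccc(NS(=O)(=O)c2cccc(CCCCCCNC(=O)/C=C/c3cccnc3)c2)c1` gives 4.78 nM. Compound 2 therefore has the lower of the two numbers, and the gap lies beyond the scatter. Compound 3 `CC(C)(C)c1ccc(NS(=O)(=O)c2cccc(CCCCCCNC(=O)/C=C/c3cccnc3)c2)cc1` differs from compound 2 in one group: 4-(tert-butyl)phenyl in place of 3-methylphenyl on a sulfonamide nitrogen, with 4-(tert-butyl)phenyl in place of 3-methylphenyl on a sulfonamide nitrogen. Among the measured compounds shown here, no measured pair shows this change alone, so the forecast is uncertain. A slight weakening within the scatter is expected, a 1.7-fold higher number from compound 2 to compound 3 (0.22 log units; within the scatter). In this assay, the estimated value for compound 3 is 8 nM, with an expected range of 1.5 nM to 40 nM.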

Compound 3, half-maximal inhibitory concentration: 24.7 nM
Compound 3: the middle estimate sits 3.1-fold (0.49 log units) below what was measured; measured number inside the range.
By their numbers in this assay, from the lowest: compound 2; then compound 3; then compound 1.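

In this assay the group on the sulfonamide nitrogen matters: 4-(tert-butyl)phenyl in place of 3-methylphenyl gives a 5.2-fold higher number from compound 2 to compound 3 (0.71 log units; beyond the scatter) as a modest loss. Even so, compound 3 at 24.7 nM stays active in the low nanomolar range, so this group with its extra carbons is tolerated at some cost. Nothing measured here explains the loss. The change swaps both the substituent and its ring position, so these two effects cannot be separated. 4-Methylphenyl or 3-(tert-butyl)phenyl on the same nitrogen would help to tell them apart.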